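Removing a trifluoromethyl group from a nucleotide-like agonist

The source may report more compounds than this note shows. Statements on the series, on what has been measured and on what is new or still open speak of the compounds shown alone.

Compound 1 `O=P(O)(O)OP(=O)(O)OP(=O)(O)OC[C@H]1O[C@@H](c2nc3cc(C(F)(F)F)ccc3s2)[C@H](O)[C@@H]1O`: > 20000 nM in a functional assay for agonist activity at P2Y purinoceptor 1 (Homo sapiens), read by FLIPR (on this read-out higher numbers stand for an effect only at larger amounts of compound and lower numbers for an effect already at smaller amounts), a limit of the assay rather than a number.
Compound 2 `O=P(O)(O)OP(=O)(O)OP(=O)(O)OC[C@H]1O[C@@H](c2nc3c(F)cc(Cl)cc3s2)[C@H](O)[C@@H]1O`: > 20000 nM in this assay, again a limit of the assay rather than a number.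

Among the compounds with values here, compound 1 stands only at a limit in this assay, and the one further value shown, that of compound 2, is a limit as well, so the two cannot be ranked against each other. Both sit at the limit of > 20000 nM in this assay, at which 2 of the 2 values shown sit. Within the data shown here, no two measured compounds differ in just one place, so no measured step is available to show how a single change moves the read-out.

Compound 3 `O=P(O)(O)OP(=O)(O)OP(=O)(O)OC[C@H]1O[C@@H](c2nc3ccccc3s2)[C@H](O)[C@@H]1O` shares the core of compound 1 and differs from it in one place: hydrogen in place of trifluoromethyl on an aromatic carbon. With every measured value sitting at the limit, there is no direction to read from the data. The step is expected to be a step that the limit leaves unreadable from compound 1 to compound 3, meaning none beyond the scatter, with compound 3 staying at or near the limit. Compound 3 is therefore estimated at 25000 nM, with a range from 5000 nM to 100000 nM, and a good chance that the assay again reports only a limit.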

Compound 3, half-maximal effective concentration: > 20000 nM
Compound 3: only a limit was reported (the forecaster's own chance of this, stated with the estimate: 80%); the middle value does not contradict the limit.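

In this assay compound 3 gives > 20000 nM, a limit of the assay rather than a number. Compound 1 also stands only at a limit, so no step from compound 1 to compound 3 can be read: the limit of > 20000 nM in this assay, at which 3 of the 3 values shown sit.

The compounds shown leave open whether hydrogen in place of trifluoromethyl on an aromatic carbon changes the read-out at all, and what change to the shared core would give a measurable value.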